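A few compounds are considered here, and "the series" means these few. Any claim that something is new, unique, unknown or untested is made for them only; others in the source may bear on it.

Compound 1, `Cc1cccc(Cn2cc(COc3ccc4c(=O)ccoc4c3)nn2)c1`: in an ADME assay on L02 cells (Homo sapiens) for cytotoxicity, read by MTT assay, with a stated time of 48 h (on this read-out higher numbers stand for weaker inhibition and lower numbers for stronger inhibition), compound 1 gives > 300000 nM, which is a limit of the assay and not a number.
Compound 2, `O=c1ccoc2cc(OCc3cn(Cc4cccc(Br)c4)nn3)ccc12`: in this assay compound 2 gives > 300000 nM, again a limit of the assay.
Compound 3, `Cc1ccccc1Cn1cc(COc2ccc3c(=O)ccoc3c2)nn1`: in this assay compound 3 gives > 300000 nM, also a limit of the assay.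

Compound 3 therefore stands at a limit, where all three measured values sit (the limit of > 300000 nM in this assay, at which 3 of the 3 values shown sit). Compound 4, `O=c1ccoc2cc(OCc3cn(Cc4ccc(F)cc4)nn3)ccc12`, has not yet been measured. It differs from compound 3 in one place: 4-fluorophenyl in place of 2-methylphenyl on a saturated chain carbon bound to an aromatic nitrogen. The measured steps that bear on this change all involve a swap of one benzyl-type group for another on the same carbon, namely a step that the two limits leave unreadable from compound 1 to compound 3, a step that the two limits leave unreadable from compound 2 to compound 3 and a step that the two limits leave unreadable from compound 1 to compound 2, and none of them can be read in size, since both ends of each step are limits. No readable step is available to expect a direction in this assay for compound 4, so a step of no readable size is expected, a step that the limit leaves unreadable from compound 3 to compound 4. Compound 4 is therefore estimated at 500000 nM, with a range from 200000 nM to 3000000 nM.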

Compound 4, half-maximal inhibitory concentration: > 300000 nM
Compound 4: a limit, no number; the forecaster's own chance of this, stated with the estimate: 85%; the middle value lies beyond the limit too.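

Compound 4 also ends at a limit and not a number, so none of its steps from compound 1, compound 2 or compound 3 can be read in this assay: the limit of > 300000 nM in this assay, at which 4 of the 4 values shown sit.

The compounds shown leave open where any true value lies and whether swapping these groups changes it at all.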